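Pyrrolidin-1-yl in place of cyclopentyl(methyl)amino

The source may report more compounds than this note shows. Statements on the series, on what has been measured and on what is new or still open speak of the compounds shown alone.

In a functional assay on RAW264.7 cells (Mus musculus), with a stated time of 3 days (on this read-out lower numbers stand for stronger inhibition and higher numbers for weaker inhibition), compound 1 `COc1cnc(-c2ccccn2)nc1N(C)C1CCCC1` gives 180 nM as its value, at the low end of the three measured numbers. Compound 2 `COc1cnc(-c2ccccn2)nc1NCc1ccccc1C` gives 220 nM and lies within the scatter of compound 1, so no order is read between those two. Compound 3 `COc1cnc(-c2ccccn2)nc1NC(C)c1ccccc1` gives 660 nM and stands higher than compound 1 by more than the scatter.

The unmeasured compound 4 `COc1cnc(-c2ccccn2)nc1N1CCCC1` carries pyrrolidin-1-yl in place of cyclopentyl(methyl)amino on an aromatic carbon of the shared core pyrrolidin-1-yl in place of cyclopentyl(methyl)amino on an aromatic carbon and is otherwise the same as compound 1. Among the measured compounds shown here, no two measured compounds differ in one place only, so the data give no direct size for this change, and none of them carries pyrrolidin-1-yl. A modest rise in the number in this assay is still expected, since compound 1 at 180 nM already sits at the low end of what has been seen, which leaves more room for a new group to land higher than lower. The expected step is a 2.2-fold higher number from compound 1 to compound 4 (0.35 log units; beyond the scatter) and its direction is held loosely. In this assay compound 4 is estimated at 400 nM with 130 nM to 1200 nM as the expected range.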

Compound 4, half-maximal inhibitory concentration: 150 nM
Compound 4: middle estimate off by 2.7-fold (0.43 log units), on the high side, within the range that was stated.
By their numbers in this assay, from the lowest: compounds 4, 1 and 2 (each within the scatter of the next); then compound 3.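

In this assay, among the compounds shown here, pyrrolidin-1-yl in place of cyclopentyl(methyl)amino gives a 1.2-fold lower number from compound 1 to compound 4 (0.08 log units; within the scatter), the first step with a single place changed. On this aromatic carbon, next to the ring nitrogen and ortho to the methoxy group, the substituent can therefore go from 7 heavy atoms to 5, and a five-membered ring of carbon only can give way to one with 1 hetero atom, with no change that can be read in this assay. The two groups share 0 hydrogen-bond donors and 1 hydrogen-bond acceptor, and nothing at hand gives a reason for the lack of a readable step.

Still open, on these data alone, is whether other cyclic amines at this place, such as azetidin-1-yl, piperidin-1-yl or morpholin-4-yl, would stay within the scatter of compound 4 or move beyond it. Also open, as far as these compounds go, is how far this result holds when the methoxy group gives way to ethoxy or hydroxy, or the pyridin-2-yl group to pyridin-3-yl or phenyl.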